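The source may report more compounds than this note shows. Statements on the series, on what has been measured and on what is new or still open speak of the compounds shown alone.

Measured compounds in a functional assay on NCI-H23 cells (Homo sapiens) for inhibition, read by sulforhodamine B assay, with a stated time of 48 h; a higher number here means that more compound is tolerated, a lower number that less compound is tolerated:

Compound 1 `O=C(Nc1cccc(-n2cc(-c3ccncc3)c(-c3ccc(Cl)c(O)c3)n2)c1)Nc1ccc(Cl)c(Cl)c1` gives > 32500 nM, a limit of the assay rather than a number.
Compound 2 `COc1cc(-c2nn(-c3cccc(NC(=O)Nc4cccc(C(F)(F)F)c4)c3)cc2-c2ccncc2)ccc1Cl` gives > 50000 nM, likewise a limit.
Compound 3 `COc1cc(-c2nn(-c3cccc(NC(=O)c4ccccc4)c3)cc2-c2ccncc2)ccc1Cl` gives > 100000 nM, again a limit.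

Within the data shown here, compound 3 thus stands nowhere definite on this scale: only a limit is known for it, and the two other values shown are limits as well, so no compound can be ordered against another. Among the measured compounds shown here, the one measured step that differs in a single place, a step that the two limits leave unreadable from compound 2 to compound 3, is left unreadable by the two limits the limit of > 50000 nM in this assay, at which 1 of the 3 values shown sits, and (the limit of > 100000 nM in this assay, at which 1 of the 3 values shown sits).

Compound 4 `COc1cc(-c2nn(-c3cccc(NC(=O)Nc4ccc(Cl)c(Cl)c4)c3)cc2-c2ccncc2)ccc1Cl` differs from compound 3 by (3,4-dichlorophenyl)amino in place of phenyl on a carbonyl carbon. The same (3,4-dichlorophenyl)amino on a carbonyl carbon is present in compound 1, which sits at the limit (the limit of > 32500 nM in this assay, at which 1 of the 3 values shown sits), and the related urea of compound 2 sits at the limit of > 50000 nM in this assay, at which 1 of the 3 values shown sits. For the measured compounds named here, every value shown is a limit, so no step of readable size bears on this change, and no step beyond the scatter can be expected in this assay in either direction; the expected step of an at least 1.6-fold lower number from compound 3 to compound 4 (0.22 log units; that floor lies within the scatter) is therefore set near zero. Compound 4 is expected to give 60000 nM, with a range of 20000 nM to 200000 nM, most likely reported again only as a limit.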

Compound 4, concentration lethal to 50% of the cells: > 50000 nM
Compound 4: no number, only a limit (the forecaster's own chance of this, stated with the estimate: 85%); the middle value lies beyond the limit too.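

In this assay compound 4 gives > 50000 nM, a limit of the assay and not a number. The steps linking compound 4 to compound 1, compound 2 and compound 3 cannot be read, as each pair holds only limits. The compounds shown leave open the actual lethal concentration of all four, and whether any of these changes shifts it.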